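A third configuration of one structure, still unmeasured

The source may report more compounds than this note shows. Statements on the series, on what has been measured and on what is new or still open speak of the compounds shown alone.

Compound 1 `Nc1ncnc2c1ncn2/C=C1\C[C@H]1[C@H](O)CO`: 72700 nM
Compound 2 `Nc1ncnc2c1ncn2/C=C1\C[C@@H]1[C@H](O)CO`: 57000 nM

Both numbers come from an ADME assay on Akata cells (Homo sapiens) for cytotoxicity; a lower number here means that less compound is tolerated, a higher number that more compound is tolerated. Going by the values given here, there, compound 2, at 57000 nM, cannot be separated from compound 1, the only other measured compound, since the two lie within the usual scatter of each other. The next compound, compound 3 `Nc1ncnc2c1ncn2/C=C1\C[C@H]1[C@@H](O)CO`, has not yet been measured. Its relation to compound 2 is purely one of configuration: the two compounds have the same atoms and bonds and differ only in configuration as drawn: 2 of 3 stereo elements differ; a stereocentre at a saturated ring carbon is drawn S in compound 2 and R in compound 3; a stereocentre at a saturated chain carbon is drawn S in compound 2 and R in compound 3. Among the compounds with values here, only one measured step bears on this change, and it involves the ring stereocentre alone. Its structural basis is the fact that compounds 1 and 2 differ only in the configuration as drawn, and it was small: a 1.3-fold lower number from compound 1 to compound 2 (0.11 log units; within the scatter). Within the data shown here, no measured step alters the chain stereocentre, so that part of the change is untested and the uncertainty is wider than the single step suggests. Given compound 1 and the size of a 1.3-fold lower number from compound 1 to compound 2 (0.11 log units; within the scatter), no change beyond the scatter is expected in this assay, and no direction is favoured. For compound 3 the estimated step is a 1.1-fold higher number from compound 2 to compound 3 (0.04 log units; within the scatter). Compound 3 is expected to give 62000 nM, with an estimated range of 28000 nM to 130000 nM.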

Compound 3, half-maximal cytotoxic concentration: 73000 nM
Beside the measured number, compound 3's estimate is 1.2-fold (0.07 log units) below it; the measured number falls inside the stated range.
By their numbers in this assay, from the lowest: compounds 2, 1 and 3 (each within the scatter of the next).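

Going by these compounds alone, compound 3 isolates the chain stereocentre, which no earlier step had changed on its own, and in this assay that inversion is a 1.0-fold higher number from compound 1 to compound 3 (0.00 log units; within the scatter). Inverting the ring and chain stereocentres together is a 1.3-fold higher number from compound 2 to compound 3 (0.11 log units; within the scatter), so the three compounds cannot be separated in this assay, whether these stereocentres are changed singly or together. Configuration is the only structural difference in this single-centre step, so it says nothing about changes of any other kind: the fact that compounds 1 and 3 differ only in the configuration as drawn

From the compounds shown here alone, the fourth combination of the ring and chain stereocentres remains open, as does the third stereo element, which is the same in all three compounds. Also open, going by these compounds, is whether a change of atoms rather than configuration, such as a carboxylic acid or a longer chain in place of the hydroxyl-bearing chain, would move the number beyond the scatter in this assay.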